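The source may hold more compounds than are shown below. What is called first, only, known or untested is meant among the compounds shown, and "the series" means these compounds.

Three compounds sharing one core have been examined in a functional assay on MCF7 cells (Homo sapiens) for cytotoxicity, read by sulforhodamine B assay, with a stated time of 24 h; on this read-out higher numbers stand for weaker inhibition and lower numbers for stronger inhibition. Compound 1 `N#CCC(=O)N/N=C1\C(=O)Nc2ccc(S(=O)(=O)N3CCOCC3)cc21` gives 27700 nM in this assay, the lowest of the three numbers, though it stands within the scatter of both its neighbours. Compound 2 `O=C1Nc2ccc(S(=O)(=O)N3CCOCC3)cc2/C1=N/c1cccc(C(F)(F)F)c1` gives 41100 nM, and compound 3 `CC(=O)c1cccc(/N=C2\C(=O)Nc3ccc(S(=O)(=O)N4CCOCC4)cc32)c1` gives 39200 nM. The step of a 1.5-fold higher number from compound 1 to compound 2 (0.17 log units; within the scatter) and the step of a 1.4-fold higher number from compound 1 to compound 3 (0.15 log units; within the scatter) both replaced the whole ((cyanomethyl)carbonyl)amino arm with an aryl group on the double-bonded nitrogen, and neither moved the number beyond the scatter; the step of a 1.0-fold lower number from compound 2 to compound 3 (0.02 log units; within the scatter) was likewise flat.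

Compound 4 `O=C1Nc2ccc(S(=O)(=O)N3CCOCC3)cc2/C1=N/NS(=O)(=O)c1ccccc1` differs from compound 1 by phenylsulfonyl in place of (cyanomethyl)carbonyl on an amine nitrogen. Within the data shown here, no measured step changes exactly this part, but the two steps from compound 1 that remove the same arm entirely were both within the scatter, so a replacement of the (cyanomethyl)carbonyl group alone is expected to give at most a change of similar size, with no clear direction. Compound 4 is therefore estimated at 30000 nM, in the range 12000 nM to 75000 nM, a step of a 1.1-fold higher number from compound 1 to compound 4 (0.03 log units; within the scatter) that is expected to stay within the scatter.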

Compound 4, half-maximal inhibitory concentration: 25300 nM
Estimate against measurement, compound 4: 1.2-fold (0.07 log units) above; the measured number falls inside the stated range.
By their numbers in this assay, from the lowest: compounds 4, 1, 3 and 2 (each within the scatter of the next).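

In this assay, the amine nitrogen also accepts phenylsulfonyl, which brings a six-membered aromatic ring and sulfur in place of the nitrile-bearing (cyanomethyl)carbonyl, with the number staying within the scatter (a 1.1-fold lower number from compound 1 to compound 4 (0.04 log units; within the scatter)). Set against the aryl groups placed directly on the double-bonded nitrogen, (phenylsulfonyl)amino also stays within the scatter (a 1.5-fold lower number from compound 3 to compound 4 (0.19 log units; within the scatter); a 1.6-fold lower number from compound 2 to compound 4 (0.21 log units; within the scatter)), so three quite different arms at this position now read alike, and the arm's outer end has yet to separate any pair of compounds. No supporting data on hand offer an explanation for this closeness.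

The compounds shown leave open whether a carboxylic acid or an amine on the phenylsulfonyl group, or a longer chain in place of it, would move the number beyond the scatter. They also leave open how much of the shared level depends on the core itself.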